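From dimethylcarbamoyl to fluoro on a shared core

The source may hold more compounds than are shown below. What is called first, only, known or untested is meant among the compounds shown, and "the series" means these compounds.

Values measured in an in vitro ADME assay on microsomes from liver (Homo sapiens) for metabolic stability; on this read-out lower numbers stand for slow clearance and higher numbers for fast clearance:
- Compound 1 `CN(C)C(=O)c1cc(Cl)c(NC(=O)N2CCN3C(=O)N([C@H]4C[C@@H]4c4ccccc4)C(=O)[C@@H]3C2)c(Cl)c1`: 49000 mL.min-1.g-1
- Compound 2 `O=C(Nc1cccnc1-c1cccc(Cl)c1)N1CCN2C(=O)N([C@H]3C[C@@H]3c3ccccc3)C(=O)[C@@H]2C1`: 90000 mL.min-1.g-1
- Compound 3 `O=C(Nc1ccnn1-c1cccc(F)c1)N1CCN2C(=O)N([C@H]3C[C@@H]3c3ccccc3)C(=O)[C@@H]2C1`: 45000 mL.min-1.g-1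

Compound 1 lies within the usual scatter of both compound 2 and compound 3. Compound 4 `O=C(Nc1c(Cl)cc(F)cc1Cl)N1CCN2C(=O)N([C@H]3C[C@@H]3c3ccccc3)C(=O)[C@@H]2C1` is not yet measured. It keeps the core of compound 1 but carries fluoro in place of dimethylcarbamoyl on an aromatic carbon. Among the measured compounds shown here, no measured pair differs in only one place, so there is no direct guide to this change. Compound 2 lacks the dimethylcarbamoyl group and gives 90000 mL.min-1.g-1, while compound 3 also lacks it and gives 45000 mL.min-1.g-1. A small upward move, probably not beyond the scatter, is therefore expected in this assay. The expected step is a 1.3-fold higher number from compound 1 to compound 4 (0.12 log units; within the scatter). For compound 4 the estimate is 65000 mL.min-1.g-1, with an expected range of 32000 mL.min-1.g-1 to 130000 mL.min-1.g-1.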

Compound 4, intrinsic clearance in microsomes: 64000 mL.min-1.g-1
Compound 4: the middle estimate sits 1.0-fold (0.01 log units) above what was measured, and the stated range covers the measured number.
By their numbers in this assay, from the lowest: compounds 3, 1, 4 and 2 (each within the scatter of the next).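

In this assay, among the compounds shown here, the swap of dimethylcarbamoyl for fluoro, on the aromatic carbon meta to two chloro groups, is the first single change that can be read: it gives a 1.3-fold higher number from compound 1 to compound 4 (0.12 log units; within the scatter) and so leaves clearance within the usual scatter. At this position, then, a group of 5 heavy atoms and a single fluorine cannot be told apart on this read-out. Nothing measured here accounts for that.

From the compounds shown here alone, whether another group at this position, such as an amine or a carboxylic acid, would move clearance beyond the scatter remains open.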